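The source may report more compounds than this note shows. Statements on the series, on what has been measured and on what is new or still open speak of the compounds shown alone.

Values measured so far in a functional assay on the whole organism (strain Sprague-Dawley) for inhibition, with Rattus norvegicus as the target, with a stated time of 10 min (on this read-out lower numbers stand for an effect already at smaller amounts and higher numbers for an effect only at larger amounts of compound), are these:
- Compound 1 `O=C(O)c1cnc(-c2ccccc2F)[nH]c1=O` gives 5 mg/kg
- Compound 2 `O=C(O)c1cnc(-c2ccccc2[N+](=O)[O-])[nH]c1=O` gives > 50 mg/kg as a limit of the assay
- Compound 3 `CCCCOc1ccccc1-c1ncc(C(=O)O)c(=O)[nH]1` gives 0.5 mg/kg
- Compound 4 `CC(C)COc1ccccc1-c1ncc(C(=O)O)c(=O)[nH]1` has not yet been measured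

Compound 3 holds the lower of the two actual numbers in this assay and its nearest neighbour is compound 1, the gap being a 10-fold lower number from compound 1 to compound 3 (1.00 log units; beyond the scatter) on this read-out. Compound 2 stands only at a limit, as the limit of > 50 mg/kg in this assay, at which 1 of the 3 values shown sits, records. Its steps, an at least 10-fold higher number from compound 1 to compound 2 (1.00 log units; beyond the scatter) and an at least 100-fold lower number from compound 2 to compound 3 (2.00 log units; beyond the scatter) in turn, are therefore bounds rather than exact sizes.

Compound 4 keeps the core of compound 3 and carries isobutoxy in place of butoxy, a change given by isopropyl in place of propyl on a saturated chain carbon bound to an oxygen on an aromatic ring in full. All measured steps replace one whole group on the aromatic ring with another, and none alters the chain itself. They show how far this assay can move, but they do not size this change directly. The same atoms stay in place here, joined differently, so a much smaller effect is expected, probably none beyond the scatter. The anchor is compound 3 at 0.5 mg/kg in this estimate. The expected change is a 1.4-fold higher number from compound 3 to compound 4 (0.15 log units; within the scatter) as estimated here. For compound 4 the estimated value is 0.7 mg/kg with an expected range from 0.2 mg/kg to 2.5 mg/kg in this assay.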

Compound 4, dose for 50% inhibition: 0.5 mg/kg
Compound 4: the middle estimate sits 1.4-fold (0.15 log units) above what was measured, and the stated range covers the measured number.
By their numbers in this assay, from the lowest: compounds 3 and 4 (each within the scatter of the next); then compound 1. At a limit, above all of these: compound 2.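

In this assay, isopropyl in place of propyl on a saturated chain carbon bound to an oxygen on an aromatic ring gives no change at the digits printed from compound 3 to compound 4 (within the scatter), so this position tolerates a rearrangement of the same atoms in the chain, which the earlier replacements of one whole group by another could not show. The isobutoxy chain also keeps the separation from the fluoro compound, with a 10-fold lower number from compound 1 to compound 4 (1.00 log units; beyond the scatter), so the lower number seen with butoxy is not confined to the unbranched chain. The separation from the nitro compound is an at least 100-fold lower number from compound 2 to compound 4 (2.00 log units; beyond the scatter), and this is only a bound, as compound 2 is recorded at a limit: the limit of > 50 mg/kg in this assay, at which 1 of the 4 values shown sits.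

The compounds shown leave open whether a longer chain such as hexyloxy, a cyclopropylmethoxy group or a chain ending in an amine would stay at the same level in this assay. They also leave open whether a shorter group such as methoxy would already give the lower number that both the butoxy and the isobutoxy chains give relative to fluoro.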